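Working notes: chloro for pyridin-3-yl, compound 2 to compound 4

The compounds below may be only part of what the source reports. "The series", "measured", "known", "first", "only" and "open" are said of these compounds alone.

Measured so far:
compound 1 `Cc1c(COCCCCO)[nH]c2ccccc2c1=O` — "not determined" (no result reported)
compound 2 `Cc1c(COc2cccc(OCC3CCOCC3)c2)[nH]c2ccc(-c3cccnc3)cc2c1=O` — > 1000 mL/min/kg
compound 3 `Cc1c(COc2cc(OCCC(C)(C)O)ccn2)[nH]c2ccccc2c1=O` — 112 mL/min/kg

In an in vitro ADME assay on microsomes from liver (Mus musculus) for metabolic stability, tested at 0.2 uM (on this read-out higher numbers stand for fast clearance and lower numbers for slow clearance), compound 3 gives 112 mL/min/kg. For compound 1 no result was reported. Compound 2 reaches only a limit of the assay, > 1000 mL/min/kg, and so sits at the ceiling of the numbers shown, the point marked by the limit of > 1000 mL/min/kg in this assay, at which 1 of the 3 values shown sits.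

Compound 4 `Cc1c(COc2cccc(OCC3CCOCC3)c2)[nH]c2ccc(Cl)cc2c1=O` differs from compound 2 in one place: chloro in place of pyridin-3-yl on an aromatic carbon. Among the compounds with values here, no step between two measured compounds covers this change, so its size is uncertain. Starting from the ceiling of compound 2, the reading can only stay at the limit or come down; a modest fall is expected, an at least 1.4-fold lower number from compound 2 to compound 4 (0.15 log units; that floor lies within the scatter), in this assay. Compound 4 is therefore expected to give 700 mL/min/kg, within 250 mL/min/kg to 1000 mL/min/kg.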

Compound 4, clearance: > 1000 mL/min/kg
Compound 4 ended at the assay's limit; the forecaster's own chance of this, stated with the estimate: 45%; middle value at least 1.4-fold (0.15 log units) from the limit.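

In this assay compound 2 and compound 4 both stand at a limit, so no step can be read between them: the limit of > 1000 mL/min/kg in this assay, at which 2 of the 4 values shown sit.

The compounds shown leave open how far either compound lies past that limit, and whether chloro in place of pyridin-3-yl changes clearance at all.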